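The compounds below may be only part of what the source reports. "The series", "measured", "known", "first", "only" and "open" are said of these compounds alone.

Compound 3 `COC(=O)c1ccccc1COc1ccc(OCCOCCNC2CCCC2)cc1` carries a 2-(methoxycarbonyl)phenyl group; in a functional assay on SK-OV-3 cells (Homo sapiens) for inhibition, read by CCK-8 assay, with a stated time of 70 h (a higher number here means a weaker inhibitor, a lower number a stronger inhibitor), compound 3 reaches only the assay limit of > 100000 nM. Compound 1 `O=[N+]([O-])c1ccc(COc2ccc(OCCOCCNC3CCCC3)cc2)cc1` gives 20300 nM in this assay, and compound 2 `Nc1ccccc1COc1ccc(OCCOCCNC2CCCC2)cc1` gives 14000 nM. The steps of an at least 4.9-fold higher number from compound 1 to compound 3 (0.69 log units; beyond the scatter) and an at least 7.1-fold higher number from compound 2 to compound 3 (0.85 log units; beyond the scatter) therefore set compound 3 at the weak end of the three numbers shown, where the limit of > 100000 nM in this assay, at which 1 of the 3 values shown sits, sits. Compound 4 `O=C(O)c1cccc(COc2ccc(OCCOCCNC3CCCC3)cc2)c1` differs from compound 3 by 3-carboxyphenyl in place of 2-(methoxycarbonyl)phenyl on a saturated chain carbon bound to an oxygen on an aromatic ring. For the measured compounds named here, no measured step exchanges a methoxycarbonyl for a carboxylic acid, so the two steps bear only indirectly; they show that compound 3, alone among the three, gave no number. For compound 4 a move of an at least 1.6-fold lower number from compound 3 to compound 4 (0.22 log units; that floor lies within the scatter) is expected, with a value estimated at 60000 nM, between 20000 nM and 200000 nM.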

Compound 4, half-maximal inhibitory concentration: > 100000 nM
Compound 4: only a limit was reported; the forecaster's own chance of this, stated with the estimate: 40%; middle value at least 1.6-fold (0.22 log units) from the limit.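

In this assay compound 4 gives > 100000 nM, a limit and not a number, so a second replacement on this saturated chain carbon ends at the limit: the limit of > 100000 nM in this assay, at which 2 of the 4 values shown sit.

The 3-carboxyphenyl group falls on the weak side of the 4-nitrophenyl and 2-aminophenyl groups, with an at least 4.9-fold higher number from compound 1 to compound 4 (0.69 log units; beyond the scatter) and an at least 7.1-fold higher number from compound 2 to compound 4 (0.85 log units; beyond the scatter). The step between the two limits cannot be read, so the 3-carboxyphenyl and 2-(methoxycarbonyl)phenyl groups cannot be ordered.

Left open is whether the limit goes with the carboxylic acid itself or with its ring position, and whether an amide or a nitrile on this ring would give a number.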